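Amide aryl variation on a shared pyrazolylpyridine core

The source may hold more compounds than are shown below. What is called first, only, known or untested is meant among the compounds shown, and "the series" means these compounds.

Measured compounds:
compound 1 `Cc1ccc(NC(=O)c2cccc(C(F)(F)F)c2)cc1-n1cc(-c2cccnc2)cn1`: 270 nM in a functional assay on K562 cells (Homo sapiens) for inhibition, read by MTT assay, with a stated time of 48 h; a lower number here means a stronger inhibitor, a higher number a weaker inhibitor
compound 2 `Cc1ccc(NC(=O)c2ccc(F)cc2)cc1-n1cc(-c2cccnc2)cn1`: 12500 nM in this assay

Compound 2 gives the highest number of the two measured; its nearest neighbour is compound 1, and the step between them was a 46-fold higher number from compound 1 to compound 2 (1.67 log units; beyond the scatter). Compound 3 `CCc1ccc(C(=O)Nc2ccc(C)c(-n3cc(-c4cccnc4)cn3)c2)cc1` differs from compound 2 by ethyl in place of fluoro on an aromatic carbon. For the measured compounds named here, the one measured step, from compound 1 to compound 2, shows that the amide aryl group matters a great deal, but it exchanges a different group and so bears only indirectly on the ethyl for fluoro change. A moderate step toward a lower number is therefore expected, with wide uncertainty. Compound 3 is expected to give 4000 nM (800 nM to 20000 nM) in this assay. This estimate means a 3.1-fold lower number from compound 2 to compound 3 (0.49 log units; beyond the scatter).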

Compound 3, half-maximal inhibitory concentration: 6520 nM
Estimate against measurement, compound 3: 1.6-fold (0.21 log units) below; the range from low to high includes it.
By their numbers in this assay, from the lowest: compound 1; then compounds 3 and 2 (each within the scatter of the next).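

Ethyl in place of fluoro gives a 1.9-fold lower number from compound 2 to compound 3 (0.28 log units; within the scatter), so on this aromatic carbon, para to a large group, the two groups are not distinguished in this read-out. The 4-ethylphenyl amide remains far from the 3-(trifluoromethyl)phenyl amide, with a 24-fold higher number from compound 1 to compound 3 (1.38 log units; beyond the scatter), so the larger ethyl does not close that gap. No supporting data bear on the reason for this result.

Still open, from the compounds shown here alone, is whether an amine, a carboxylic acid or a longer chain on this carbon would separate from ethyl and fluoro. The compounds shown also cannot separate the effect of the trifluoromethyl group from that of its place on the ring.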